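This account rests on a few compounds, and the source may have more. Where it says the series, first, only, none or still open, it means among the compounds named here.

Measured so far:
Compound 1 `FC(F)(F)c1ccc(Nc2cc(-c3ccncc3)ncn2)cc1` in an ADME assay on BaF3 cells (Mus musculus) for cytotoxicity (a lower number here means that less compound is needed, a higher number that more compound is needed for the effect), gives > 10000 nM, a limit of the assay and not a number.
Compound 2 `NC(=O)Cn1ncc2c(Nc3ccc(OC(F)(F)F)cc3)ncnc21` in this assay gives 3300 nM.

Going by the values given here, compound 1 stands at the limit of > 10000 nM in this assay, at which 1 of the 2 values shown sits; no number is known for it, and compound 2 carries the only measured value in the pair. Compound 3 `Fc1ccc(Nc2cc(-c3ccncc3)ncn2)cc1` is still to be measured in this assay. It differs from compound 1 by fluoro in place of trifluoromethyl on an aromatic carbon. Among the compounds with values here, no step between measured compounds matches this change, so nothing measured sets its size. Because compound 1 sits at the limit of > 10000 nM in this assay, at which 1 of the 2 values shown sits, only a step downward could appear as a number, and no step beyond the scatter is expected from this change. Compound 3 is expected to give about 12000 nM, in the range 4000 nM to 40000 nM. The implied step that the limit leaves unreadable from compound 1 to compound 3 is estimated to stay within the scatter.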

Compound 3, half-maximal effective concentration: > 10000 nM
Compound 3: no number, only a limit (the forecaster's own chance of this, stated with the estimate: 60%); the middle value does not contradict the limit.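

Compound 1 and compound 3 both sit at a limit of the assay rather than a number in this assay, so no step can be read for fluoro in place of trifluoromethyl: the limit of > 10000 nM in this assay, at which 2 of the 3 values shown sit.

The compounds shown leave open whether this change has any effect on the core of compound 1.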